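Dichloro versus monochloro purine cores on ortho-chloromethylbenzyl

The compounds below may be only part of what the source reports. "The series", "measured", "known", "first", "only" and "open" are said of these compounds alone.

Measured so far:
compound 1 `ClCc1ccc(Cn2cnc3c(Cl)ncnc32)cc1` — > 100000 nM
compound 2 `ClCc1ccccc1Cn1cnc2c(Cl)nc(Cl)nc21` — 370 nM

For the measured compounds named here, in a functional assay on K562 cells (Homo sapiens) for cytotoxicity, read by sulforhodamine B assay, with a stated time of 48 h (on this read-out lower numbers stand for stronger inhibition of growth and higher numbers for weaker inhibition of growth), compound 2 gives 370 nM, the only true number in the set. For compound 1 the value is a limit of the assay, (the limit of > 100000 nM in this assay, at which 1 of the 2 values shown sits), and not a number. Compound 3 `ClCc1ccccc1Cn1cnc2c(Cl)ncnc21` differs from compound 2 by hydrogen in place of chloro on an aromatic carbon. Going by the values given here, no measured step covers this change, so the direction is uncertain; a loss of growth inhibition beyond the scatter is expected. The expected step is an 8.1-fold higher number from compound 2 to compound 3 (0.91 log units; beyond the scatter). Compound 3 is estimated at 3000 nM, within 800 nM to 30000 nM.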

Compound 3, concentration for total growth inhibition: 5120 nM
Estimate against measurement, compound 3: 1.7-fold (0.23 log units) below; the measured number falls inside the stated range.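

In this assay, hydrogen in place of chloro on the aromatic carbon between two ring nitrogen atoms gives a 14-fold higher number from compound 2 to compound 3 (1.14 log units; beyond the scatter). For the compounds shown here, this is the first measured step at this place, and it shows that growth inhibition in this pair depends on the chloro there. Compound 1 is a limit of the assay, and no step to it can be read: the limit of > 100000 nM in this assay, at which 1 of the 3 values shown sits.

Still open, going by these compounds, is whether an amine or a methoxy group on this carbon would match chloro or hydrogen. A single pair also cannot show whether the step carries over to other benzyl groups.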